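This account rests on a few compounds, and the source may have more. Where it says the series, first, only, none or still open, it means among the compounds named here.

Of the compounds shown here, three that share one core have been measured in a functional assay on MOLT-4 cells (Homo sapiens) for cytotoxicity, read by sulforhodamine B assay, with a stated time of 48 h, tested at 0.01 uM; on this read-out higher numbers stand for a weaker effect at the one concentration tested and lower numbers for a stronger effect. Compound 1 `COc1cc(-c2cc(/C=C/C(=O)c3ccc(N)cc3)[nH]n2)cc(OC)c1OC` gives 101%, compound 2 `COc1ccc(-c2cc(/C=C/C(=O)c3ccc(OC)c(OC)c3)[nH]n2)cc1` gives 105%, and compound 3 `COc1cc(-c2cc(/C=C/C(=O)c3ccc(Cl)c(Cl)c3)[nH]n2)cc(OC)c1OC` gives 98%. All three numbers sit close to the level that means no effect at the one concentration tested. Compound 1 stands second highest of the three; compound 3 is nearest and compound 2 furthest, and both gaps lie within the scatter. Among the compounds with values here, the only pair that differs in one place shows a number 3 percentage points lower from compound 1 to compound 3 (within the scatter), so replacing the group on the carbonyl carbon did not move the read-out beyond the scatter.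

Compound 4 `COc1ccc(-c2cc(/C=C/C(=O)c3ccc(N)cc3)[nH]n2)cc1OC` has not yet been measured. It differs from compound 1 in one place: hydrogen in place of methoxy on an aromatic carbon. Within the data shown here, no measured step removes a methoxy group, so the step from compound 1 to compound 3 is the closest guide, and that step stayed within the scatter. With compound 1 giving 101% and every other number near the same level, no step beyond the scatter is expected. The expected step is no change at the digits printed from compound 1 to compound 4 (within the scatter). Compound 4 is therefore estimated to give 101%, with a range from 92% to 110%.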

Compound 4, a percentage reported as activity, at one concentration (the size of the read-out at that concentration, not a potency): 108%
Compound 4: the middle estimate sits 7 percentage points below what was measured; measured number inside the range.
By their numbers in this assay, from the lowest: compounds 3, 1, 2 and 4 (each within the scatter of the next).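

In this assay, within the data shown here, the change of hydrogen in place of methoxy on an aromatic carbon gives a number 7 percentage points higher from compound 1 to compound 4 (within the scatter) and is the first step in the set on the methoxy-bearing six-membered aromatic ring, whereas the earlier step changed the group on a carbonyl carbon. Neither single change has moved the read-out beyond the scatter, and compound 1 and compound 4 both sit close to the level that means no effect, so this comparison shows only that neither form has a visible effect at this one low concentration, not that the methoxy group is unimportant for activity in general. No measurement shown bears on this result, and none offers an explanation for it.

The compounds shown leave open whether a hydroxy group, a fluorine atom or an ethoxy group on this aromatic carbon would move the read-out away from the no-effect level. They also leave open how compound 1 and compound 4 would compare at a higher concentration, where the read-out might start to respond and a real difference could show.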